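Butyl to 2,4-difluorophenyl on the sulfonyl sulfur

The source may report more compounds than this note shows. Statements on the series, on what has been measured and on what is new or still open speak of the compounds shown alone.

Compound 1 `CCCCS(=O)(=O)Nc1cc(-c2ccc3ncnc(NCCN(C)C)c3c2)cnc1OC`: 3240 nM
Compound 2 `CCCCS(=O)(=O)Nc1cc(-c2ccc3ncnc(NCc4ccncc4)c3c2)cnc1OC`: 18700 nM

In a functional assay on MCF7 cells (Homo sapiens) for antiproliferative activity, read by sulforhodamine B assay, with a stated time of 72 h (a higher number here means a weaker inhibitor, a lower number a stronger inhibitor), compound 2 has the higher of the two numbers, which makes it the weaker inhibitor of the pair. Compound 3 `COc1ncc(-c2ccc3ncnc(NCc4ccncc4)c3c2)cc1NS(=O)(=O)c1ccc(F)cc1F` keeps the pyridin-4-yl of compound 2 and differs from it in one place: 2,4-difluorophenyl in place of butyl on a sulfonyl sulfur. Going by the values given here, only one measured step is available, a 5.8-fold higher number from compound 1 to compound 2 (0.76 log units; beyond the scatter), and it lies elsewhere in the molecule, on a saturated chain carbon bound to a nitrogen on an aromatic ring. Among the compounds with values here, no measured pair tests a change on the sulfonyl sulfur, so that step offers only a rough guide to size and none to direction. A modest move towards a lower number in this assay is nevertheless expected, though with little certainty. The expected change is a 4.7-fold lower number from compound 2 to compound 3 (0.67 log units; beyond the scatter). For compound 3 the estimated value is 4000 nM, with an expected range of 600 nM to 20000 nM.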

Compound 3, half-maximal inhibitory concentration: 22500 nM
The estimate for compound 3 lay 5.6-fold (0.75 log units) below the measured number, outside the stated range (above it).
By their numbers in this assay, from the lowest: compound 1; then compounds 2 and 3 (each within the scatter of the next).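

With the pyridin-4-yl held constant, 2,4-difluorophenyl in place of butyl on the sulfonyl sulfur gives a 1.2-fold higher number from compound 2 to compound 3 (0.08 log units; within the scatter) in this assay. Going by these compounds alone, this is the first measured change at this position, and it shows that, in this pair, exchanging an open butyl chain for an aromatic ring carrying two fluorine atoms leaves the number within the scatter. Nothing in the data shown explains this result.

The compounds shown leave open whether the same exchange would read the same way with the (dimethylamino)methyl of compound 1 in place of the pyridin-4-yl. They also leave open how other groups on the sulfonyl sulfur, such as a methyl, an unsubstituted phenyl or a chain ending in an amine, would compare with butyl.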